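The source may hold more compounds than are shown below. What is called first, only, known or untested is meant among the compounds shown, and "the series" means these compounds.

Measured in a functional assay on Bel-7402 cells (Homo sapiens) for antiproliferative activity, read by MTT assay, with a stated time of 72 h; on this read-out lower numbers stand for stronger inhibition and higher numbers for weaker inhibition:
Compound 1 `O=C(Nc1cccc(I)c1)C(Cl)Cl` gives 5390 nM.
Compound 2 `COc1cccc(NC(=O)C(Cl)Cl)c1` gives 54800 nM.
Compound 3 `O=C(Nc1ccc(I)cc1)C(Cl)Cl` gives 11900 nM.

Compound 1 and compound 3 have the same atoms joined differently; the difference between the two cores is not broken down here. Compound 3 stands second highest of the three numbers, nearest to compound 1 and furthest from compound 2. From compound 1 to compound 2 the change is methoxy in place of iodo on an aromatic carbon, and it made a 10-fold higher number from compound 1 to compound 2 (1.01 log units; beyond the scatter). Compound 4 `COc1ccc(NC(=O)C(Cl)Cl)cc1` is not yet measured; from compound 3 it differs by methoxy in place of iodo on an aromatic carbon. The two changes are the same kind of change, not the same: in compound 1 the place is meta to a group of 6 heavy atoms, in compound 3 it is para to a group of 6 heavy atoms. Among the compounds with values here, on this single precedent, compound 4 is expected to show a step of a 7.6-fold higher number from compound 3 to compound 4 (0.88 log units; beyond the scatter) in this assay, because the only comparable step was a 10-fold higher number from compound 1 to compound 2 (1.01 log units; beyond the scatter). Compound 4 is estimated at 90000 nM, between 30000 nM and 250000 nM.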

Compound 4, half-maximal inhibitory concentration: 192000 nM
For compound 4 the middle estimate is 2.1-fold (0.33 log units) below the measured one, within the range that was stated.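

In this assay, methoxy in place of iodo on an aromatic carbon gave a 16-fold higher number from compound 3 to compound 4 (1.21 log units; beyond the scatter), and the step is of the same direction and comparable size on the two cores: the same change on two cores in this assay, a 10-fold higher number (1.01 log units; beyond the scatter) from compound 1 to compound 2 and a 16-fold higher number (1.21 log units; beyond the scatter) from compound 3 to compound 4, 1.6-fold (0.20 log units) apart, within the scatter of two such steps. Within these four compounds, the change therefore carries from one core to the other. Within the data shown here, the agreement rests on only two pairs, however, and it neither explains the step nor shows that it would hold on a core outside this set.

From the compounds shown here alone, how bromo, an amine or a carboxylic acid would compare with iodo and methoxy on the same aromatic carbon remains open. Also open, going by these compounds, is whether a longer chain such as ethoxy would behave like methoxy.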